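The source may hold more compounds than are shown below. What is called first, only, known or untested is meant among the compounds shown, and "the series" means these compounds.

In a functional assay on HEK293 cells for antagonist activity at proteinase-activated receptor 4 (Homo sapiens), read by FLIPR and calcium flux, with a stated time of 30 min (a lower number here means a stronger inhibitor, a higher number a weaker inhibitor), compound 1 `c1ccc2oc(-c3cn4nc(C5CC5)sc4n3)cc2c1` gives 530 nM, while compound 2 `CCOc1nn2cc(-c3cc4ccccc4o3)nc2s1` gives 67 nM. For the measured compounds named here, the one measured step, a 7.9-fold lower number from compound 1 to compound 2 (0.90 log units; beyond the scatter), swaps cyclopropyl for ethoxy on the shared core. On these two numbers compound 2 stands lowest, with compound 1 its nearest neighbour at a higher value, beyond the scatter.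

Compound 3 `COc1nn2cc(-c3cc4ccccc4o3)nc2s1` keeps everything of compound 2 but one change: hydrogen in place of methyl on a saturated chain carbon bound to an oxygen on an aromatic ring. The ethoxy thus becomes methoxy, ethyl to methyl. Going by the values given here, no measured step matches this trimming directly; the step from compound 1 to compound 2 touched the same place but exchanged a ring for an oxygen-bearing chain and was only modest, so a far smaller trimming is expected to move the number little, most likely within the scatter, perhaps slightly towards a weaker inhibitor, which is the expected 1.5-fold higher number from compound 2 to compound 3 (0.17 log units; within the scatter). Compound 3 is estimated at 100 nM, with a range from 35 nM to 300 nM.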

Compound 3, half-maximal inhibitory concentration: 4 nM
For compound 3 the middle estimate is 25-fold (1.40 log units) above the measured one, outside the stated range (below it).
By their numbers in this assay, from the lowest: compound 3; then compound 2; then compound 1.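

In this assay, this position proves far more sensitive than the first pair could show. Trimming ethyl to methyl on the oxygen removes a single carbon, yet it gives a 17-fold lower number from compound 2 to compound 3 (1.22 log units; beyond the scatter), a large step, whereas the earlier exchange of the cyclopropyl ring for ethoxy was only modest. Set against the cyclopropyl of compound 1, methoxy gives a 130-fold lower number from compound 1 to compound 3 (2.12 log units; beyond the scatter), so the choice of group at this one place alone spans a wide range of potency, though nothing shown here explains why one carbon counts for so much.

From the compounds shown here alone, with only cyclopropyl, ethoxy and methoxy at this place, the shape of the trend remains open. A longer chain such as propoxy, a hydroxyl group or an amine there would show whether methoxy is a narrow optimum or part of a broader pattern.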